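Furan-3-yl replacing 5-bromothiophen-2-yl in the amine series

A few compounds are considered here, and "the series" means these few. Any claim that something is new, unique, unknown or untested is made for them only; others in the source may bear on it.

Compound 3 `C[C@H]1[C@H](NCc2ccc(Br)s2)C[C@H]2C[C@@H]1C2(C)C` gives 43000 nM in an ADME assay on MDCK cells (Canis lupus familiaris) for cytotoxicity, read by microscopy, with a stated time of 48 h (a higher number here means that more compound is tolerated, a lower number that less compound is tolerated), the highest of the three numbers in hand. Compound 2 `CSc1ccc(CN[C@@H]2C[C@H]3C[C@@H]([C@H]2C)C3(C)C)s1` gives 25000 nM, and the pair differ by a 1.7-fold higher number from compound 2 to compound 3 (0.24 log units; within the scatter). Compound 1 `C[C@H]1[C@H](NCc2ccc(C(C)(C)C)s2)C[C@H]2C[C@@H]1C2(C)C` gives 780 nM, and the step is a 55-fold higher number from compound 1 to compound 3 (1.74 log units; beyond the scatter); likewise a 32-fold higher number from compound 1 to compound 2 (1.51 log units; beyond the scatter). Compound 4 `C[C@H]1[C@H](NCc2ccoc2)C[C@H]2C[C@@H]1C2(C)C` is unmeasured. It differs from compound 3 by furan-3-yl in place of 5-bromothiophen-2-yl on a saturated chain carbon bound to an amine nitrogen.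

The measured steps all change a substituent on an aromatic carbon while keeping the same ring; none exchanges the ring itself, so the bearing is indirect. Exchanging tert-butyl for bromo or methylsulfanyl gave large steps, whereas bromo against methylsulfanyl stayed within the scatter. Among the compounds with values here, the present change removes the bromo and alters the ring, which has no precedent here. A modest downward move is expected, since compound 3 sits at the top of the three numbers and compound 1 shows a much lower value 780 nM. The expected step is a 2.2-fold lower number from compound 3 to compound 4 (0.33 log units; beyond the scatter), and compound 4 is estimated at 20000 nM, within 4000 nM to 80000 nM.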

Compound 4, minimum cytotoxic concentration: > 100000 nM
Compound 4: a limit, no number; the forecaster's own chance of this, stated with the estimate: 10%; at least 5.0-fold (0.69 log units) between middle value and limit.
By their numbers in this assay, from the lowest: compound 1; then compounds 2 and 3 (each within the scatter of the next). At a limit, above all of these: compound 4.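

In this assay compound 4 gives > 100000 nM, which is a limit of the assay and not a number. Exchanging the whole ring group on the saturated chain carbon bound to an amine nitrogen gives an at least 2.3-fold higher number from compound 3 to compound 4 (0.36 log units; beyond the scatter), so this change moves the read-out upward from the top of the earlier values. The earlier steps shown here only changed a substituent on an aromatic carbon, and this first step involving a ring exchange can be read only as a lower bound: the limit of > 100000 nM in this assay, at which 1 of the 4 values shown sits.

Within the data shown here, the single step changes the ring and removes the bromo together, so their separate contributions cannot be told apart; an unsubstituted thiophen-2-yl or a phenyl group would be needed to separate them. As far as these compounds go, whether a tert-butyl group on furan-3-yl would return the value towards that of compound 1 also remains open.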